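Amide aryl swap in a sulfoxide series: cytotoxicity

The source may report more compounds than this note shows. Statements on the series, on what has been measured and on what is new or still open speak of the compounds shown alone.

Measured so far:
compound 1, `COc1cc2nc(SCC(=O)Nc3ccc(C(F)(F)F)cc3)nc(Nc3c(C)cc(/C=C/C#N)cc3C)c2cc1OC`: > 211000 nM
compound 2, `COc1cc2nc([S+]([O-])CC(=O)Nc3ccc(Cl)cc3)nc(Nc3c(Cl)cc(/C=C/C#N)cc3Cl)c2cc1OC`: 14400 nM

In an ADME assay on MT4 cells (Homo sapiens) for cytotoxicity, read by MTT assay, with a stated time of 5 days (on this read-out higher numbers stand for lower toxicity in this test and lower numbers for higher toxicity in this test), compound 1 gives only a limit of the assay, > 211000 nM. Compound 2 holds the only number shown and gives 14400 nM in this assay. Compound 3, `COc1ccccc1NC(=O)C[S+]([O-])c1nc(Nc2c(Cl)cc(/C=C/C#N)cc2Cl)c2cc(OC)c(OC)cc2n1`, awaits measurement there. It differs from compound 2 in one place: 2-methoxyphenyl in place of 4-chlorophenyl on an amide-type nitrogen. Within the data shown here, no step between measured compounds is available, so the size of this change is untested. The expected step is a 1.4-fold higher number from compound 2 to compound 3 (0.14 log units; within the scatter), nothing beyond the usual scatter. Compound 3 is therefore estimated at 20000 nM, between 7000 nM and 60000 nM.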

Compound 3, half-maximal cytotoxic concentration: > 204000 nM
Compound 3 ended at the assay's limit; the forecaster's own chance of this, stated with the estimate: 15%; at least 10-fold (1.00 log units) between middle value and limit.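

In this assay, 2-methoxyphenyl in place of 4-chlorophenyl on an amide-type nitrogen gives an at least 14-fold higher number from compound 2 to compound 3 (1.15 log units; beyond the scatter), so a change at this position alone can go beyond the scatter. Compound 3 gives > 204000 nM, which is a limit of the assay and not a number. The size of this step therefore has a floor but no measured top.

The compounds shown leave open whether the loss of the chlorine or the arrival of the methoxy carries this step. An unsubstituted phenyl or a 4-methoxyphenyl on the same nitrogen would separate the two.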